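The source may hold more compounds than are shown below. What is called first, only, known or untested is meant among the compounds shown, and "the series" means these compounds.

Of the compounds shown here, three built on one shared core have been measured in an assay on HEK243 cells for displacement of a labelled ligand from Neuronal acetylcholine receptor; alpha3/beta4 (Homo sapiens), read by scintillation counting, with a stated time of 5 min; on this read-out lower numbers stand for stronger inhibition and higher numbers for weaker inhibition. Compound 1 `CN1CCC[C@H]1COc1cc(O)cc(C#CCCCCO)c1` carries a 6-hydroxyhex-1-yn-1-yl group on the core and gives 3100 nM. Compound 2 `CN1CCC[C@H]1COc1cc(O)cc(-c2ccccc2)c1` carries a phenyl group in its place and gives 200 nM, a change of a 16-fold lower number from compound 1 to compound 2 (1.19 log units; beyond the scatter). Compound 3 `CN1CCC[C@H]1COc1cc(O)cc(-c2ccc(O)cc2)c1` carries a 4-hydroxyphenyl group and gives 30 nM. With a 100-fold lower number from compound 1 to compound 3 (2.01 log units; beyond the scatter) and a 6.7-fold lower number from compound 2 to compound 3 (0.82 log units; beyond the scatter), both beyond the scatter, compound 3 stands as the most potent of the three measured compounds.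

Compound 4 `CN1CCC[C@H]1COc1cc(-c2ccc(O)cc2)cc([N+](=O)[O-])c1` differs from compound 3 in one place: nitro in place of hydroxy on an aromatic carbon. For the measured compounds named here, none of the measured steps tests this position, since the hydroxy on the core is present in compound 1, compound 2 and compound 3 alike; all three steps concern the other substituent. Going by the values given here, the only step that involves a hydroxy at all, a 6.7-fold lower number from compound 2 to compound 3 (0.82 log units; beyond the scatter), sits on the distal ring and is therefore only a loose guide. Among the compounds with values here, with no direct precedent, the expectation is a loss of moderate size, a 3.3-fold higher number from compound 3 to compound 4 (0.52 log units; beyond the scatter), rather than a gain. Starting from compound 3 at 30 nM, compound 4 is estimated at 100 nM, with a likely range from 30 nM to 400 nM.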

Compound 4, inhibition constant: 122 nM
Compound 4: middle estimate off by 1.2-fold (0.09 log units), on the low side; low and high end bracket the measured number.
By their numbers in this assay, from the lowest: compound 3; then compounds 4 and 2 (each within the scatter of the next); then compound 1.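

For the compounds shown here, this is the first look at the hydroxy on the shared core, which stayed the same in compounds 1 to 3, and in this assay the position proves sensitive to change: nitro in its place gives a 4.1-fold higher number from compound 3 to compound 4 (0.61 log units; beyond the scatter). That step is modest, smaller than the large one at the other substituent (a 100-fold lower number from compound 1 to compound 3 (2.01 log units; beyond the scatter)), so this hydroxy can be exchanged for a quite different group while the compound stays well below the number of compound 1. The swap alters several things at once, since nitro has more heavy atoms than hydroxy and, unlike hydroxy, no hydrogen-bond donor, and nothing shown gives a reason for the step.

A plain hydrogen, a methoxy group or an amine at this place would help show whether the hydrogen-bond donor or the size of the group tracks the change in number. Going by these compounds, whether nitro has a similar effect with the unsubstituted phenyl of compound 2, or with the 6-hydroxyhex-1-yn-1-yl chain of compound 1, also remains open.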